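A few compounds are considered here, and "the series" means these few. Any claim that something is new, unique, unknown or untested is made for them only; others in the source may bear on it.

Going by the values given here, in a functional assay on Jurkat cells (Homo sapiens) for antiproliferative activity, read by MTT assay, with a stated time of 72 h (a higher number here means a weaker inhibitor, a lower number a stronger inhibitor), compound 1 `COc1ccc(-c2ncnn2-c2cc(OC)c(OC)c(OC)c2)cc1` gives 50 nM, the lowest number measured so far and the strongest of the three compounds. Compound 3 `COc1cc(-n2ncnc2-c2ccc(OC(C)C)cc2)cc(OC)c1OC` gives 650 nM, the nearest value. Compound 2 `COc1cc(-n2ncnc2-c2ccc(OC(F)(F)F)cc2)cc(OC)c1OC` reaches only a limit of the assay, > 10000 nM.

Both of these compounds alter the methoxy group of compound 1. Isopropyl in place of methyl on the oxygen gives a 13-fold higher number from compound 1 to compound 3 (1.11 log units; beyond the scatter), and trifluoromethyl in place of methyl gives an at least 200-fold higher number from compound 1 to compound 2 (2.30 log units; beyond the scatter). Compound 4 `COc1ccccc1-c1ncnn1-c1cc(OC)c(OC)c(OC)c1` has the same atoms joined differently, with 2-methoxyphenyl in place of 4-methoxyphenyl on an aromatic carbon.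

Among the compounds with values here, no measured step moves the methoxy group, so the evidence is indirect. Still, both changes made to compound 1 raised the number, the smaller of them being a 13-fold higher number from compound 1 to compound 3 (1.11 log units; beyond the scatter), so a rise of similar or greater size is expected here. The expected step in this assay is a 40-fold higher number from compound 1 to compound 4 (1.60 log units; beyond the scatter). For compound 4 the estimated value is 2000 nM, with an expected range from 200 nM to 10000 nM.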

Compound 4, half-maximal inhibitory concentration: > 10000 nM
Compound 4: no number, only a limit; the forecaster's own chance of this, stated with the estimate: 30%; middle value at least 5.0-fold (0.69 log units) from the limit.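

Compound 2 and compound 3 changed what sits on the oxygen, whereas compound 4 keeps the methoxy group intact and changes only where it stands on the phenyl ring. In this assay, 2-methoxyphenyl in place of 4-methoxyphenyl, with the same atoms in both groups, gives an at least 200-fold higher number from compound 1 to compound 4 (2.30 log units; beyond the scatter), so the place of the methoxy group alone is enough for a large loss in this pair. The value of compound 4, > 10000 nM, is a limit, so the full size of this step stays unknown and compound 4 cannot be ranked against compound 2: the limit of > 10000 nM in this assay, at which 2 of the 4 values shown sit.

The compounds shown leave open whether any group at the 2-position of the phenyl ring gives such a loss, or only methoxy. A hydroxyl, a fluorine or an amine there would bear on that question.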